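This account rests on a few compounds, and the source may have more. Where it says the series, first, only, none or still open, it means among the compounds named here.

Compound 1 `COC(=O)c1ccc(C2SCC(=O)N2c2ccc(N3CCN(Cc4cccc(C)c4)CC3)cn2)c(OC)c1`: > 100000 nM (a limit)
Compound 2 `COC(=O)c1ccc(C2SCC(=O)N2c2ccc(N3CCN(Cc4cccc([N+](=O)[O-])c4)CC3)cn2)c(OC)c1`: 68700 nM
Compound 3 `COC(=O)c1ccc(C2SCC(=O)N2c2ccc(N3CCN(S(=O)(=O)c4ccc(F)cc4)CC3)cn2)c(OC)c1`: > 100000 nM (a limit)

These three compounds were tested in a functional assay on K562 cells (Homo sapiens) for antiproliferative activity, read by MTT assay and trypan blue exclusion, with a stated time of 72 h; a lower number here means a stronger inhibitor, a higher number a weaker inhibitor. Compound 1 has no exact value and stands at the limit of > 100000 nM in this assay, at which 2 of the 3 values shown sit.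

The next compound, compound 4 `COC(=O)c1ccc(C2SCC(=O)N2c2ccc(N3CCN(S(=O)(=O)c4c(C)cc(C)cc4C)CC3)cn2)c(OC)c1`, carries (2,4,6-trimethylphenyl)sulfonyl in place of 3-methylbenzyl on an amine nitrogen in a ring.

The closest measured change puts (4-fluorophenyl)sulfonyl on that same nitrogen, and it gives a step that the two limits leave unreadable from compound 1 to compound 3. Compound 3, which carries that group, reaches only a limit, > 100000 nM. The two remaining steps offer little more, as an at least 1.4-fold lower number from compound 1 to compound 2 (0.16 log units; that floor lies within the scatter) and an at least 1.4-fold higher number from compound 2 to compound 3 (0.16 log units; that floor lies within the scatter) each have a floor within the scatter.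

The data therefore give no reason to expect a gain in this assay, and the assay may again report only a limit. The expected step is a number no higher from compound 1 to compound 4 (the limit leaves the size open), with none expected beyond the scatter. Compound 4 is estimated at 100000 nM, with an expected range of 50000 nM to 200000 nM.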

Compound 4, half-maximal inhibitory concentration: 53500 nM
Estimate against measurement, compound 4: 1.9-fold (0.27 log units) above; the measured number falls inside the stated range.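

In this assay, (2,4,6-trimethylphenyl)sulfonyl on the amine nitrogen gives an exact value, with an at least 1.8-fold lower number from compound 1 to compound 4 (0.27 log units; that floor lies within the scatter), and placing 2,4,6-trimethylphenyl in place of 4-fluorophenyl on the sulfonyl sulfur gives an at least 1.8-fold lower number from compound 3 to compound 4 (0.27 log units; that floor lies within the scatter). So a sulfonyl group at this position does not always leave the compound at the assay limit, and the comparison with the 3-nitrobenzyl compound gives a 1.3-fold lower number from compound 2 to compound 4 (0.11 log units; within the scatter), which means that these two different groups cannot be told apart here. Both steps from limits remain floors, and the exact size of each stays unknown: the limit of > 100000 nM in this assay, at which 2 of the 4 values shown sit.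

The compounds shown leave open what a smaller group on this nitrogen, such as methylsulfonyl or acetyl, would give. They also leave open whether a free amine on the aromatic ring of the sulfonyl group would change the result.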